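The compounds below may be only part of what the source reports. "The series", "measured", "known", "first", "only" and "open" are said of these compounds alone.

In an ADME assay on microsomes from liver (Rattus norvegicus) for metabolic stability (a lower number here means slower removal, a higher number faster removal of the compound), compound 1 (`O=C(Nc1cnc(-n2nccn2)c(Cl)c1)Nc1cnc2cc(Cl)nn2c1C1CC1`) gives 50.4 mL.min-1.g-1. Compound 2 (`CO[C@@H](C)c1c(NC(=O)Nc2cnc(-n3nccn3)c(Cl)c2)cnc2cc(Cl)nn12`) carries 1-methoxyethyl in place of cyclopropyl and reports < 25 mL.min-1.g-1, which is a limit of the assay and not a number. It therefore stands at the low end of what can be read here, as the limit of < 25 mL.min-1.g-1 in this assay, at which 1 of the 2 values shown sits, records.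

Compound 3 (`O=C(Nc1cnc(-n2nccn2)c(Cl)c1)Nc1cnc2cc(Cl)nn2c1C1CCOCC1`) has oxan-4-yl in place of 1-methoxyethyl on an aromatic carbon. The group that enters is a ring, as cyclopropyl is, and it contains oxygen, as 1-methoxyethyl does.

For the measured compounds named here, only one measured step bears on this change: an at least 2.0-fold lower number from compound 1 to compound 2 (0.30 log units; that floor lies within the scatter). On these data alone, its floor lies within the scatter, so the true size of that step remains open. With features of both groups, compound 3 is expected to fall between the other two compounds, probably nearer the limit than compound 1. The estimate means an at least 1.2-fold higher number from compound 2 to compound 3 (0.07 log units; that floor lies within the scatter), an expected rise that may not clear the scatter. For compound 3 the expected value is 30 mL.min-1.g-1, with an estimated range from 18 mL.min-1.g-1 to 55 mL.min-1.g-1.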

Compound 3, intrinsic clearance in microsomes: 25.5 mL.min-1.g-1
For compound 3 the middle estimate is 1.2-fold (0.07 log units) above the measured one; measured number inside the range.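

Swapping cyclopropyl for oxan-4-yl gives a 2.0-fold lower number from compound 1 to compound 3 (0.30 log units; within the scatter) in this assay, so these two rings cannot be told apart in this measurement, and a six-membered ring containing oxygen now has a real number at this position. Swapping 1-methoxyethyl for oxan-4-yl gives an at least 1.0-fold higher number from compound 2 to compound 3 (0.00 log units; that floor lies within the scatter), a step with a limit at one end that cannot be read for its size. Compound 2 reports a limit of the assay and not a number, which leaves the open-chain group without a value of its own here: the limit of < 25 mL.min-1.g-1 in this assay, at which 1 of the 3 values shown sits.

On these data alone, whether the oxygen in the ring matters at all stays open, and cyclohexyl, the same ring with carbon in place of that oxygen, would separate the effect of the ring from the effect of the oxygen. Also open, as far as these compounds go, is how a ring carrying an amine, such as piperidin-4-yl, would read in this assay, and how far the true number for compound 2 lies from those of the two ring compounds.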